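Extending the Dibutylamino Chain of Compound 2

A few compounds are considered here, and "the series" means these few. Any claim that something is new, unique, unknown or untested is made for them only; others in the source may bear on it.

Within the data shown here, in a functional assay on LNCaP cells (Homo sapiens) for antiproliferative activity, read by WST assay, with a stated time of 3 days (on this read-out higher numbers stand for weaker inhibition and lower numbers for stronger inhibition), compound 1 (`CCOc1c(-c2cc(OC)c(OC)c(OC)c2)oc2ccccc2c1=O`) gives 5400 nM and compound 2 (`CCCCN(CCCC)CCCOc1c(-c2cc(OC)c(OC)c(OC)c2)oc2ccccc2c1=O`) gives 9000 nM, so compound 2 stands within the scatter of the only other measured value. Compound 3 (`CCCCN(CCCC)CCCCCOc1c(-c2cc(OC)c(OC)c(OC)c2)oc2ccccc2c1=O`) differs from compound 2 as follows: 2-(dibutylamino)ethyl in place of dibutylamino on a saturated chain carbon, three bonds along the chain from an oxygen on an aromatic ring. Among the measured compounds shown here, the one measured step that bears on this change is a 1.7-fold higher number from compound 1 to compound 2 (0.22 log units; within the scatter). Adding the dibutylamino chain thus produced no step beyond the scatter, and no step beyond the scatter is expected here either. The expected step is a 1.1-fold lower number from compound 2 to compound 3 (0.05 log units; within the scatter). Compound 3 is estimated at 8000 nM, with an expected range of 3000 nM to 20000 nM.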

Compound 3, half-maximal inhibitory concentration: 7800 nM
Beside the measured number, compound 3's estimate is 1.0-fold (0.01 log units) above it, and the stated range covers the measured number.
By their numbers in this assay, from the lowest: compounds 1, 3 and 2 (each within the scatter of the next).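

In this assay, 2-(dibutylamino)ethyl in place of dibutylamino gives a 1.2-fold lower number from compound 2 to compound 3 (0.06 log units; within the scatter), so this change on the chain leaves the number within the scatter. Set against compound 1, 3-(dibutylamino)propyl in place of hydrogen gives a 1.4-fold higher number from compound 1 to compound 3 (0.16 log units; within the scatter), so this longer chain, like the shorter one in compound 2, does not separate from compound 1. No measurement at hand offers an explanation for this flat result.

The compounds shown leave open whether a still longer chain would give a step beyond the scatter. They also leave open whether dimethylamino, a piperidine or a carboxylic acid at the chain end would do so.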